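The source may hold more compounds than are shown below. What is called first, only, known or untested is meant among the compounds shown, and "the series" means these compounds.

Working notes on a small set of cyanoguanidines sharing a dimethylsulfamoyl phenol core. Compound 1 `Cc1ccccc1N/C(=N\C#N)Nc1ccc(Cl)c(S(=O)(=O)N(C)C)c1O` gives 378 nM in an assay on CHO cells for displacement of a labelled ligand from C-X-C chemokine receptor type 1 (Homo sapiens); a lower number here means a stronger inhibitor, a higher number a weaker inhibitor. Compound 2 `CN(C)S(=O)(=O)c1c(Cl)ccc(N/C(=N/C#N)Nc2ccccc2F)c1O` gives 1550 nM in this assay; the change is fluoro in place of methyl on an aromatic carbon, and the step of a 4.1-fold higher number from compound 1 to compound 2 (0.61 log units; beyond the scatter) is a loss in potency. Compound 3 `Cc1ccc(N/C(=N/C#N)Nc2ccccc2Br)c(O)c1S(=O)(=O)N(C)C` gives 187 nM in this assay, the lowest of the three numbers; the difference between the cores of compound 3 and compound 1 is not broken down here. Compound 4 `CN(C)S(=O)(=O)c1c(F)ccc(N/C(=N/C#N)Nc2ccccc2Br)c1O` has not been measured; it differs from compound 3 by fluoro in place of methyl on an aromatic carbon. This is the same kind of change as in the earlier pair, but at a different place: ortho to a dimethylsulfamoyl group, meta to a hydroxy group and para to a large group, rather than ortho to a large group. Going by these compounds, a weakening step is expected, a 1.9-fold higher number from compound 3 to compound 4 (0.27 log units; within the scatter), smaller than the earlier one because that earlier step a 4.1-fold higher number from compound 1 to compound 2 (0.61 log units; beyond the scatter) was made at another position and the present place is untested. Compound 4 is expected to give about 350 nM in this assay, between 120 nM and 1000 nM.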

Compound 4, half-maximal inhibitory concentration: 192 nM
Beside the measured number, compound 4's estimate is 1.8-fold (0.26 log units) above it; the measured number falls inside the stated range.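

In this assay, fluoro in place of methyl on an aromatic carbon does not carry over with one size of step from one core to another: the same change on two cores in this assay, a 4.1-fold higher number (0.61 log units; beyond the scatter) from compound 1 to compound 2 and a 1.0-fold higher number (0.01 log units; within the scatter) from compound 3 to compound 4, 4.0-fold (0.60 log units) apart, beyond the scatter of two such steps. The new step, a 1.0-fold higher number from compound 3 to compound 4 (0.01 log units; within the scatter), stands against the earlier loss in potency, a 4.1-fold higher number from compound 1 to compound 2 (0.61 log units; beyond the scatter), so the result of this change on one core is a poor guide to its result on the other. What sets the two steps apart is not shown: the change sits at a different place in each pair and the rest of the structure also differs, and two pairs cannot separate these factors.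

The compounds shown leave open whether the same change at this place, ortho to a dimethylsulfamoyl group, would give a similar step with other groups on the far aromatic ring. They also leave open how an amine or a methoxy group at this place would compare with fluoro and methyl.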